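Methyl for fluoro on the aryl ring of a pyrrole acid series

The source may hold more compounds than are shown below. What is called first, only, known or untested is meant among the compounds shown, and "the series" means these compounds.

Three members of one series have been measured in an assay on cells for inhibition of Palmitoleoyl-protein carboxylesterase NOTUM variant C330S (Homo sapiens), read by fluorescence, with a stated time of 40 min; a lower number here means a stronger inhibitor, a higher number a weaker inhibitor. Compound 1 `Cc1cc(C(=O)O)c(C)n1-c1ccccc1F` gives 3300 nM in this assay. Compound 3 `Cc1ccccc1-n1c(C)cc(C(=O)O)c1C` gives 2200 nM in this assay, and the change from compound 1 to compound 3 is methyl in place of fluoro on an aromatic carbon, a step of a 1.5-fold lower number from compound 1 to compound 3 (0.18 log units; within the scatter). Compound 2 `Cc1cc(C(=O)O)c(C)n1-c1cccc(F)c1` gives 1500 nM in this assay; it has the same atoms as compound 1 joined differently, and the difference between the two cores is not broken down here. Compound 2 and compound 3 sit within the scatter of each other, while compound 1 reads higher than compound 2 by more than the scatter.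

Compound 4 `Cc1cccc(-n2c(C)cc(C(=O)O)c2C)c1` has not yet been measured in this assay. It relates to compound 2 by methyl in place of fluoro on an aromatic carbon. This is the same kind of change as from compound 1 to compound 3, but there the place was ortho to a large group, whereas here it is meta to a large group. Resting on the step of a 1.5-fold lower number from compound 1 to compound 3 (0.18 log units; within the scatter), the step from compound 2 to compound 4 is expected to be a 1.5-fold lower number from compound 2 to compound 4 (0.18 log units; within the scatter). Compound 4 is therefore estimated at 1000 nM, between 400 nM and 2500 nM.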

Compound 4, half-maximal inhibitory concentration: 1500 nM
Compound 4: middle estimate off by 1.5-fold (0.18 log units), on the low side, and the stated range covers the measured number.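

In this assay, methyl in place of fluoro on an aromatic carbon, meta to a large group, gives no change at the digits printed from compound 2 to compound 4 (within the scatter). Set beside the earlier step, the change reads alike on the two cores, with no difference between the steps that can be told apart: the same change on two cores in this assay, a 1.5-fold lower number (0.18 log units; within the scatter) from compound 1 to compound 3 and no change at the digits printed (within the scatter) from compound 2 to compound 4, 1.5-fold (0.18 log units) apart, within the scatter of two such steps. This shows that in these two pairs the exchange of fluoro for methyl stays within the scatter wherever it was placed, but it rests on two pairs alone and does not show that the change would behave the same way on other cores of the series or say why the numbers stay so close.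

The compounds shown carry only fluoro or methyl as the substituent on the aromatic ring, so it remains open how chloro, methoxy or an amine would read at these places. Also open, going by these compounds, is how the series would read with an amide in place of the carboxylic acid.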